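Adding a Methoxy Group to the Core of Compound 2

The compounds below may be only part of what the source reports. "The series", "measured", "known", "first", "only" and "open" are said of these compounds alone.

Measured so far:
compound 1, `COc1ccc2c(c1)/C(=C/c1c(-c3ccncc3)nc3sccn13)C(=O)N2C`: 93200 nM
compound 2, `COc1nc2sc(C)cn2c1/C=C1/C(=O)Nc2ccccc21`: 96300 nM

Of the compounds shown here, two have been tested in a functional assay on cells (Ovarian carcinoma cell, Homo sapiens) for cytotoxicity, read by sulforhodamine B assay, with a stated time of 48 h; a lower number here means that less compound is tolerated, a higher number that more compound is tolerated. Compound 1 gives 93200 nM in this assay, and compound 2 gives 96300 nM in this assay. On these numbers compound 2 stands alongside compound 1: the gap between them is within the usual scatter, so neither can be called the more or less tolerated of the two.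

Compound 3, `COc1ccc2c(c1)/C(=C\c1c(OC)nc3sc(C)cn13)C(=O)N2`, has not yet been measured. It differs from compound 2 by methoxy in place of hydrogen on an aromatic carbon. Within the data shown here, no pair of measured compounds shows this change, so there is no measured step to lean on. With both measured values so close together, the expected step in this assay is small, a 1.0-fold lower number from compound 2 to compound 3 (0.01 log units; within the scatter), and not expected to exceed the scatter in either direction. Compound 3 is estimated at 95000 nM, with a range from 40000 nM to 220000 nM.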

Compound 3, concentration lethal to 50% of the cells: 87600 nM
The estimate for compound 3 lay 1.1-fold (0.04 log units) above the measured number, and the stated range covers the measured number.
By their numbers in this assay, from the lowest: compounds 3, 1 and 2 (each within the scatter of the next).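

In this assay, among these compounds, putting methoxy in place of hydrogen on this aromatic carbon, which is meta to one fused ring and para to another, gives a 1.1-fold lower number from compound 2 to compound 3 (0.04 log units; within the scatter) and so offers the first measured look at this position. For this one change, the added oxygen and carbon leave compound 3 indistinguishable from compound 2 in this cell test, so the swap has no effect that can be read here. No accompanying measurement bears on this result.

A single substituent on a single carbon cannot show whether the position is generally insensitive to change. On these data alone, it remains open whether an amine, a carboxylic acid or a longer chain such as butoxy at this carbon would shift the number beyond the scatter.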